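Hydrogen in place of methoxy: a small step expected

The compounds below may be only part of what the source reports. "The series", "measured", "known", "first", "only" and "open" are said of these compounds alone.

Compound 1 `COc1cc(OC)c(C(=O)/C=C/c2ccccc2OC)c(OC)c1`: 4500 nM
Compound 2 `COc1cccc(/C=C/C(=O)c2c(OC)cc(OC)cc2OC)c1`: 3900 nM

In a functional assay on Caco-2 cells (Homo sapiens) for cytotoxicity, with a stated time of 48 h (a higher number here means a weaker inhibitor, a lower number a stronger inhibitor), compound 2 gives 3900 nM, a number that cannot be separated from that of compound 1. Compound 3 `COc1cc(OC)c(C(=O)/C=C/c2ccccc2)c(OC)c1` follows from compound 2 by one change, hydrogen in place of methoxy on an aromatic carbon. Among the measured compounds shown here, only one measured step bears on this, and it relocates the methoxy rather than removing it: a 1.2-fold lower number from compound 1 to compound 2 (0.06 log units; within the scatter). For the measured compounds named here, no measured compound lacks that group, so this guidance is limited, and no step beyond the scatter is expected. The expected change is a 1.3-fold higher number from compound 2 to compound 3 (0.11 log units; within the scatter). For compound 3 the estimated value is 5000 nM, with an expected range of 2000 nM to 12000 nM.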

Compound 3, half-maximal inhibitory concentration: 5800 nM
For compound 3 the middle estimate is 1.2-fold (0.06 log units) below the measured one; measured number inside the range.
By their numbers in this assay, from the lowest: compounds 2, 1 and 3 (each within the scatter of the next).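

In this assay, among the compounds shown here, the earlier compounds only relocated the methoxy, whereas compound 3 shows what happens when it is replaced by hydrogen (with a 1.5-fold higher number from compound 2 to compound 3 (0.17 log units; within the scatter) and a 1.3-fold higher number from compound 1 to compound 3 (0.11 log units; within the scatter)). Phenyl therefore cannot be separated from either 3-methoxyphenyl or 2-methoxyphenyl at this place, so neither the presence of this methoxy nor its location shows any effect beyond the scatter across these three compounds. No measurement available here offers an explanation for this.

As far as these compounds go, it remains open whether an amine or a carboxylic acid at this place would move the number beyond the scatter. The contribution of the methoxy groups on the other side of the shared core is also left open.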